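A few compounds are considered here, and "the series" means these few. Any claim that something is new, unique, unknown or untested is made for them only; others in the source may bear on it.

The shared core is the same in every compound here, and they differ only in the group attached to a nitrogen on an aromatic ring. Compound 1 `O=c1cc(NCc2cccc(F)c2)sc2c([N+](=O)[O-])cc(C(F)(F)F)cc12` carries 3-fluorobenzyl there; in an ADME assay on Vero cells (Chlorocebus sabaeus) for cytotoxicity, read by MTT assay, with a stated time of 48 h (a higher number here means a weaker inhibitor, a lower number a stronger inhibitor), compound 1 gives > 64 ug/mL, which is a limit of the assay and not a number. Compound 2 `O=c1cc(Nc2ccccc2)sc2c([N+](=O)[O-])cc(C(F)(F)F)cc12` carries phenyl, and in this assay compound 2 gives > 64 ug/mL, again a limit. Compound 3 `O=c1cc(NC2CCCCC2)sc2c([N+](=O)[O-])cc(C(F)(F)F)cc12` carries cyclohexyl, and in this assay compound 3 gives > 64 ug/mL, also a limit. Because all three values sit at the same limit (the limit of > 64 ug/mL in this assay, at which 3 of the 3 values shown sit), the steps a step that the two limits leave unreadable from compound 1 to compound 2, a step that the two limits leave unreadable from compound 1 to compound 3 and a step that the two limits leave unreadable from compound 2 to compound 3 cannot be sized, so compound 3 stands at the limit alongside the others. Compound 4 `O=c1cc(NCc2ccc(F)cc2)sc2c([N+](=O)[O-])cc(C(F)(F)F)cc12` differs from compound 3 by 4-fluorobenzyl in place of cyclohexyl on a nitrogen on an aromatic ring. Nothing measured here separates one side group from another in this assay, and compound 1, which carries 3-fluorobenzyl, sits at the limit. Compound 4 is therefore expected to show no step beyond the scatter, a step that the limit leaves unreadable from compound 3 to compound 4, and to sit at or past the limit again. The estimate for compound 4 in this assay is 80 ug/mL, ranging from 40 ug/mL to 200 ug/mL.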

Compound 4, half-maximal inhibitory concentration: > 64 ug/mL
Compound 4 was reported as a limit; the forecaster's own chance of this, stated with the estimate: 85%; the middle value does not contradict the limit.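

In this assay compound 4 gives > 64 ug/mL, a limit of the assay and not a number. Its steps to compound 1, compound 2 and compound 3 cannot be read: the limit of > 64 ug/mL in this assay, at which 4 of the 4 values shown sit.

The compounds shown leave open whether these four side groups differ at all in this assay.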